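The source may hold more compounds than are shown below. What is called first, only, known or untested is meant among the compounds shown, and "the series" means these compounds.

Going by the values given here, compound 1, with structure `Nc1cc(N)c2nc(-c3ccccc3)c(Oc3ccc(Cl)c(Cl)c3)nc2c1`, is the only compound in this set with an actual number in a functional assay on OVCAR-5 cells (Homo sapiens) for inhibition, read by sulforhodamine B assay, with a stated time of 48 h; a lower number here means a stronger inhibitor of growth, a higher number a weaker inhibitor of growth: compound 1 gives 58900 nM. Compound 2, with structure `CCOC(=O)[C@H](CCC(=O)O)NC(=O)c1ccc(CNc2nc3cc(N)cc(N)c3nc2-c2ccccc2)cc1`, reaches only a limit of the assay in this assay, where compound 2 gives < 100000 nM. Compound 3, with structure `CCOC(=O)[C@H](CCC(=O)O)NC(=O)c1ccc(Sc2nc3cc(N)cc(N)c3nc2-c2ccccc2)cc1`, likewise reaches only a limit in this assay, where compound 3 gives < 100000 nM. The picture for the shared core is therefore thin, resting on the limit of < 100000 nM in this assay, at which 2 of the 3 values shown sit, and a single number.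

Compound 4, with structure `COc1ccc(Sc2nc3cc(N)cc(N)c3nc2-c2ccccc2)cc1`, differs from compound 1 in one place: (4-methoxyphenyl)sulfanyl in place of 3,4-dichlorophenoxy on an aromatic carbon. Among the compounds with values here, no measured step resembles this change, so the direction is open. Because the limit of < 100000 nM in this assay, at which 2 of the 3 values shown sit, shows that two compounds with other groups at this carbon give only a limit, the step is not expected to take compound 4 far from compound 1; a step of a 1.5-fold lower number from compound 1 to compound 4 (0.17 log units; within the scatter) is estimated, not beyond the scatter. Compound 4 is thus expected to give about 40000 nM in this assay, with a likely range from 8000 nM to 100000 nM.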

Compound 4, concentration for total growth inhibition: < 100000 nM
Compound 4: a limit, no number; the forecaster's own chance of this, stated with the estimate: 30%; the middle value does not contradict the limit.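

In this assay, going by these compounds alone, compound 4 gives < 100000 nM, which is a limit and not a number, so no step from compound 1 to compound 4 can be read. Whether the group on this aromatic carbon shifts growth inhibition at all stays open, with most values for the shared core resting on one limit: the limit of < 100000 nM in this assay, at which 3 of the 4 values shown sit.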